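Ethoxy to arylamino swap on the shared core

The source may report more compounds than this note shows. Statements on the series, on what has been measured and on what is new or still open speak of the compounds shown alone.

Compound 1 `CCOC1=C(C(=O)c2ccccc2)C(c2ccc(Br)cc2)N(CCCn2ccnc2)C1=O` gives 28900 nM in a functional assay on NCI-H1299 cells (Homo sapiens) for antiproliferative activity, read by MTT assay, with a stated time of 72 h; on this read-out higher numbers stand for weaker inhibition and lower numbers for stronger inhibition.
Compound 2 `CCCCCOC1=C(C(=O)c2ccccc2)C(c2ccc(Br)cc2)N(CCCn2ccnc2)C1=O` gives 10300 nM in this assay.
Compound 3 `O=C(C1=C(Nc2ccc(Cl)cc2)C(=O)N(CCCn2ccnc2)C1c1ccc(Br)cc1)c1ccccc1` gives 25000 nM in this assay.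

Compound 1 stands highest of the three numbers; compound 3 is nearest and within the scatter, compound 2 furthest, with a 2.8-fold lower number from compound 1 to compound 2 (0.45 log units; beyond the scatter).

Compound 4 `O=C(C1=C(Nc2ccc(OC(F)(F)F)cc2)C(=O)N(CCCn2ccnc2)C1c1ccc(Br)cc1)c1ccccc1` differs from compound 1 as follows: (4-(trifluoromethoxy)phenyl)amino in place of ethoxy on a double-bonded ring carbon.

Within the data shown here, the one measured step that bears on this is the ethoxy-to-arylamino swap at the same position, a 1.2-fold lower number from compound 1 to compound 3 (0.06 log units; within the scatter), which stayed within the scatter. The step of a 2.4-fold higher number from compound 2 to compound 3 (0.39 log units; beyond the scatter) concerns pentyloxy and so is less direct. No step beyond the scatter is therefore expected in this assay for compound 4, at most a slight drop, as a 1.3-fold lower number from compound 1 to compound 4 (0.12 log units; within the scatter).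

Compound 4 is estimated at 22000 nM, with a range of 8000 nM to 60000 nM.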

Compound 4, half-maximal inhibitory concentration: 11500 nM
Compound 4: the middle estimate sits 1.9-fold (0.28 log units) above what was measured, and the stated range covers the measured number.
By their numbers in this assay, from the lowest: compounds 2 and 4 (each within the scatter of the next); then compounds 3 and 1 (each within the scatter of the next).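

In this assay the group on the aromatic ring of the arylamino substituent matters: trifluoromethoxy in place of chloro gives a 2.2-fold lower number from compound 3 to compound 4 (0.34 log units; beyond the scatter) and so separates two compounds with the same arylamino link. The swap for ethoxy now also passes the scatter, with a 2.5-fold lower number from compound 1 to compound 4 (0.40 log units; beyond the scatter) as its size, and compound 4 cannot be told from the pentyloxy compound, with a 1.1-fold higher number from compound 2 to compound 4 (0.05 log units; within the scatter) as the gap. No measurement here explains these steps.

Going by these compounds, a carboxylic acid or a dimethylamino group in place of trifluoromethoxy on the aromatic carbon remains open. So does a chain longer than pentyloxy on the double-bonded ring carbon.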